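4-Fluorophenyl in place of 2,4-dihydroxyphenyl on the shared core

This account rests on a few compounds, and the source may have more. Where it says the series, first, only, none or still open, it means among the compounds named here.

Values measured in a functional assay on SW982 cells (Homo sapiens) for inhibition, read by MTT assay, with a stated time of 72 h (a lower number here means a stronger inhibitor, a higher number a weaker inhibitor), are as follows.

Compound 1 `COc1ccc(C(=O)/C=C/c2cc(OC)c(OC)cc2OC)cc1` gives 60500 nM
Compound 2 `COc1cc(OC)c(OC)cc1/C=C/C(=O)c1ccccc1` gives > 150000 nM, a limit of the assay
Compound 3 `COc1cc(OC)c(OC)cc1/C=C/C(=O)c1ccc(O)cc1O` gives 32400 nM

Within the data shown here, only two of these values are numbers, and they stand level (a 1.9-fold lower number from compound 1 to compound 3 (0.27 log units; within the scatter)). Compound 4 `COc1cc(OC)c(OC)cc1/C=C/C(=O)c1ccc(F)cc1` carries 4-fluorophenyl in place of 2,4-dihydroxyphenyl on a carbonyl carbon. Among the measured compounds shown here, two measured steps bear on this change, both beyond the scatter and at least modest: 2,4-dihydroxyphenyl in place of phenyl (an at least 4.6-fold lower number from compound 2 to compound 3 (0.66 log units; beyond the scatter)) and hydrogen in place of methoxy (an at least 2.4-fold higher number from compound 1 to compound 2 (0.39 log units; beyond the scatter)). Compound 1 keeps a number at 60500 nM without 2,4-dihydroxyphenyl, so the change need not take compound 4 out of the range of measured numbers. A modest step to a higher number is expected (a 2.2-fold higher number from compound 3 to compound 4 (0.33 log units; beyond the scatter)). For compound 4 the estimated value is 70000 nM, with an expected range from 30000 nM to 150000 nM.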

Compound 4, half-maximal inhibitory concentration: 32500 nM
Beside the measured number, compound 4's estimate is 2.2-fold (0.33 log units) above it; the measured number falls inside the stated range.
By their numbers in this assay, from the lowest: compounds 3, 4 and 1 (each within the scatter of the next). At a limit, above all of these: compound 2.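

In this assay, the hydrogen-bond donors of 2,4-dihydroxyphenyl prove dispensable on this carbonyl carbon, since 4-fluorophenyl, which has none, stands level with it (a 1.0-fold higher number from compound 3 to compound 4 (0.00 log units; within the scatter)). Fluoro also stands level with methoxy (a 1.9-fold lower number from compound 1 to compound 4 (0.27 log units; within the scatter)), while fluoro in place of hydrogen gives an at least 4.6-fold lower number from compound 2 to compound 4 (0.66 log units; beyond the scatter), so among these compounds only the unsubstituted phenyl of compound 2 stands apart. The value of compound 2 is a limit, so that last step has a number on one side only: the limit of > 150000 nM in this assay, at which 1 of the 4 values shown sits.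

From the compounds shown here alone, whether an amine or a carboxylic acid in place of fluoro would shift the number beyond the scatter remains open.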